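Acetoxy styryl compounds at the assay limit

The source may report more compounds than this note shows. Statements on the series, on what has been measured and on what is new or still open speak of the compounds shown alone.

Measured so far:
compound 1 `CC(=O)Oc1ccccc1/C=C/c1nc2ccccc2c(=O)[nH]1` gives > 25000 nM (a limit)
compound 2 `CC(=O)Oc1cccc(/C=C/c2nc3ccccc3c(=O)[nH]2)c1` gives > 25000 nM (a limit)

Both entries come from an ADME assay on NHDF cells (Homo sapiens) for antiproliferative activity, with a stated time of 72 h (on this read-out higher numbers stand for weaker inhibition and lower numbers for stronger inhibition), and neither is a number. Compound 1 stands only at a limit of this assay and has no exact value. The same holds for compound 2, so the pair shows the limit of > 25000 nM in this assay, at which 2 of the 2 values shown sit, and cannot be ranked.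

Compound 3 `CC(=O)Oc1ccc(/C=C/c2nc3ccccc3c(=O)[nH]2)c(OC(C)=O)c1` has not been measured. It differs from compound 1 by acetoxy in place of hydrogen on an aromatic carbon, meta to an acetoxy group and para to a large group (acetoxy in place of hydrogen on an aromatic carbon). Within the data shown here, no measured step covers this change. Among the measured compounds shown here, with the limit of > 25000 nM in this assay, at which 2 of the 2 values shown sit, as the only guide, no shift beyond the scatter is expected in this assay and no direction can be favoured. The expected change is a step that the limit leaves unreadable from compound 1 to compound 3 and remains small. The estimated value for compound 3 is 30000 nM, with an expected range of 12000 nM to 60000 nM.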

Compound 3, half-maximal inhibitory concentration: > 25000 nM
Compound 3 gave a limit, no number (the forecaster's own chance of this, stated with the estimate: 75%); the middle value lies beyond the limit too.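

In this assay compound 1 and compound 3 both stand only at a limit, so no step can be read between them. The compounds shown leave open what acetoxy in place of hydrogen on an aromatic carbon does to antiproliferative activity and how far past the limit each compound lies.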